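The source may report more compounds than this note shows. Statements on the series, on what has been measured and on what is new or still open speak of the compounds shown alone.

Compound 1, `CCc1onc(NS(=O)(=O)c2ccc(C(C)(C)C)cc2)c1Sc1cccc(OC)c1`, gives 2800 nM in an assay on COS-7 cells for displacement of a labelled ligand from Endothelin receptor type B (Sus scrofa); a lower number here means a stronger inhibitor, a higher number a weaker inhibitor.
Compound 2, `COc1cccc(Sc2c(NS(=O)(=O)c3ccc(C(C)(C)C)cc3)noc2CCCCC=O)c1`, gives 20 nM in this assay.

Going by the values given here, compound 2 stands lowest of the two numbers so far; its nearest neighbour is compound 1, and the step between them was a 140-fold lower number from compound 1 to compound 2 (2.15 log units; beyond the scatter). The unmeasured compound 3, `COc1cccc(Sc2c(NS(=O)(=O)c3ccc(C(C)(C)C)cc3)noc2C)c1`, is reached from compound 2 by hydrogen in place of 3-formylpropyl on a saturated chain carbon bound to an aromatic carbon, so that the long chain bearing the formyl group is cut back to a methyl on the shared core.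

Among the compounds with values here, the one measured step that bears on this is the step from compound 1 to compound 2, a 140-fold lower number from compound 1 to compound 2 (2.15 log units; beyond the scatter), which added the formyl-bearing chain and produced the large gain. Compound 3 removes that chain again and goes one carbon shorter than compound 1. Because of a 140-fold lower number from compound 1 to compound 2 (2.15 log units; beyond the scatter), compound 3 is expected to lose most or all of that gain, with the result expected to be a 150-fold higher number from compound 2 to compound 3 (2.18 log units; beyond the scatter) in this assay. Compound 3 is therefore estimated at 3000 nM, in the range 800 nM to 12000 nM.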

Compound 3, half-maximal inhibitory concentration: 300 nM
For compound 3 the middle estimate is 10-fold (1.00 log units) above the measured one, and the stated range ends above it.
By their numbers in this assay, from the lowest: compound 2; then compound 3; then compound 1.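

Going by these compounds alone, the 4-formylbutyl chain of compound 2 keeps a real advantage over the methyl of compound 3 in this assay, at a 15-fold higher number from compound 2 to compound 3 (1.18 log units; beyond the scatter), yet this is a smaller step than the one separating compound 2 from compound 1. The shortest chain does not give the highest number: compound 3 falls between the other two, with a 9.3-fold lower number from compound 1 to compound 3 (0.97 log units; beyond the scatter), so among these three compounds the number does not follow chain length, and removing a single methyl from the chain of compound 1 already moves the result beyond the scatter. Nothing among the data accounts for either of these steps.

The compounds shown leave open whether the advantage of compound 2 belongs to the formyl group or to the length of its chain, a question that a plain pentyl chain carrying no formyl group would address. On these data alone, it also remains open how this position would respond to a carboxylic acid or an amine at the end of the same chain, or to hydrogen in place of the methyl of compound 3.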